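The source may report more compounds than this note shows. Statements on the series, on what has been measured and on what is new or still open speak of the compounds shown alone.

In a functional assay on HepG2 cells (Homo sapiens) for antiproliferative activity, read by MTT assay, with a stated time of 72 h (a lower number here means a stronger inhibitor, a higher number a weaker inhibitor), compound 3 `COc1cc2c(Nc3ccc(C#N)cc3)ncnc2cc1OCCCN1CCc2ccccc2C1` gives > 100000 nM, which is a limit of the assay. Compound 1 `COc1cc2c(Nc3ccc(C#N)cc3)ncnc2cc1OCCCN(C)Cc1ccccc1` gives > 100000 nM, also a limit, so both sit at the limit of > 100000 nM in this assay, at which 2 of the 3 values shown sit. Only compound 2 `COc1cc2c(Nc3ccc(C#N)cc3)ncnc2cc1OCCCN1CCC(O)CC1` gives a number, 67900 nM. In compound 4 `CCN1CCN(CCCOc2cc3ncnc(Nc4ccc(C#N)cc4)c3cc2OC)CC1`, 4-ethylpiperazin-1-yl replaces 1,2,3,4-tetrahydroisoquinolin-2-yl on a saturated chain carbon, three bonds along the chain from an oxygen on an aromatic ring (4-ethylpiperazin-1-yl in place of 1,2,3,4-tetrahydroisoquinolin-2-yl on a saturated chain carbon, three bonds along the chain from an oxygen on an aromatic ring). Three similar swaps bear on this: an at least 1.4-fold higher number from compound 2 to compound 3 (0.16 log units; that floor lies within the scatter) and an at least 1.4-fold lower number from compound 1 to compound 2 (0.16 log units; that floor lies within the scatter) have floors within the scatter, while a step that the two limits leave unreadable from compound 1 to compound 3 cannot be sized. A small drop or no change beyond the scatter is therefore expected in this assay, and the expected step is an at least 1.4-fold lower number from compound 3 to compound 4 (0.15 log units; that floor lies within the scatter). For compound 4 the estimated value is 70000 nM, with an expected range of 25000 nM to 150000 nM.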

Compound 4, half-maximal inhibitory concentration: 9580 nM
The estimate for compound 4 lay 7.3-fold (0.86 log units) above the measured number; the measured number lies below the stated range.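

In this assay, within the data shown here, swapping the group on this saturated chain carbon can change the number beyond the scatter, which no earlier step showed: an at least 10-fold lower number from compound 3 to compound 4 (1.01 log units; beyond the scatter), an at least 10-fold lower number from compound 1 to compound 4 (1.01 log units; beyond the scatter) and a 7.1-fold lower number from compound 2 to compound 4 (0.85 log units; beyond the scatter). Compound 4 is therefore the strongest of the four. The first two steps are floors rather than full sizes, because compound 1 and compound 3 each give a limit: the limit of > 100000 nM in this assay, at which 2 of the 4 values shown sit.

On these data alone, it remains open whether the step comes from the ethyl group or from the second ring nitrogen. Piperazin-1-yl, 4-methylpiperazin-1-yl and morpholin-4-yl on the same chain would help separate these two parts.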